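The compounds below may be only part of what the source reports. "The series", "measured", "known", "first", "only" and "open" are said of these compounds alone.

Compound 1 `O=C(O)C[C@@H]1CCCN1c1ccc(Oc2ccc(Cl)cc2Cl)cc1` gives 3200 nM in a functional assay on cells for agonist activity at Free fatty acid receptor 1 (Mus musculus), read by FLIPR and calcium flux, with a stated time of 100 s (a higher number here means that more compound is needed for the effect, a lower number that less compound is needed), compound 2 `O=C(O)C[C@@H]1CCCN1c1ccc(Oc2ccccc2F)cc1` gives 6900 nM, and compound 3 `Cc1cccc(Oc2ccc(N3CCC[C@H]3CC(=O)O)cc2)c1` gives 2400 nM. Compound 2 thus stands highest of the three, with the step of a 2.2-fold higher number from compound 1 to compound 2 (0.33 log units; beyond the scatter) and the step of a 2.9-fold lower number from compound 2 to compound 3 (0.46 log units; beyond the scatter) both beyond the scatter. Compound 4 `O=C(O)C[C@@H]1CCCN1c1ccc(Oc2ccccc2-c2ccccc2)cc1` differs from compound 2 by phenyl in place of fluoro on an aromatic carbon. Among the measured compounds shown here, no measured step exchanges one group on that ring for another at the same place; the steps of a 2.2-fold higher number from compound 1 to compound 2 (0.33 log units; beyond the scatter) and a 2.9-fold lower number from compound 2 to compound 3 (0.46 log units; beyond the scatter) only show that changing the aryl group moves this assay by modest amounts, and that compound 2 is the weakest starting point. Compound 4 is therefore expected to give a modestly lower number, an estimated 2.8-fold lower number from compound 2 to compound 4 (0.44 log units; beyond the scatter), at 2500 nM with a range of 700 nM to 9000 nM.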

Compound 4, half-maximal effective concentration: 1300 nM
Compound 4: middle estimate off by 1.9-fold (0.28 log units), on the high side; the range from low to high includes it.
By their numbers in this assay, from the lowest: compounds 4, 3 and 1 (each within the scatter of the next, the first and the last beyond it); then compound 2.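

In this assay, among the compounds shown here, phenyl in place of fluoro gives a 5.3-fold lower number from compound 2 to compound 4 (0.72 log units; beyond the scatter), and this is the first step that exchanges one group for another at a single place on that ring. It shows that this place, ortho to a large group, tolerates an added six-membered aromatic ring, with six heavy atoms entering where one left, and that the number falls rather than rises. Going by these compounds, whether a ring is needed there stays open, as does how a methyl group, an amine or a carboxylic acid at the same carbon would compare. Nothing available bears on why the number falls.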